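The source may report more compounds than this note shows. Statements on the series, on what has been measured and on what is new or still open speak of the compounds shown alone.

Of the compounds shown here, three that share one core have been measured so far: compound 1 `Cc1c(C(=O)Nc2c(F)cc(-c3cccc(F)c3)cc2F)nc2ccc(C(F)(F)F)cc2c1O`, compound 2 `CCOc1ccc2nc(C(=O)Nc3c(F)cc(-c4cccc(F)c4)cc3F)c(C)c(C(=O)O)c2c1` and compound 3 `COc1ccc2nc(C(=O)Nc3c(F)cc(-c4cccc(F)c4)cc3F)c(C)c(C(=O)O)c2c1`. In a functional assay on A-375 cells (Homo sapiens) for antiproliferative activity, read by MTT assay, with a stated time of 24 h, tested at 33.33 ug/mL (a higher number here means a stronger effect of the compound at the concentration tested, a lower number a weaker effect), compound 1 gives 61.3%, compound 2 gives 51.2% and compound 3 gives 44.5%, so compound 3 stands lowest of the three, although its gap to compound 2 lies within the scatter. Going by the values given here, the only measured step, a number 6.7 percentage points lower from compound 2 to compound 3 (within the scatter), concerns a different group and is itself within the scatter. Compound 4 `Cc1c(C(=O)Nc2c(F)cc(-c3cccc(F)c3)cc2F)nc2ccc(C(F)(F)F)cc2c1C(=O)O` differs from compound 3 by trifluoromethyl in place of methoxy on an aromatic carbon. Among the compounds with values here, no measured step changes this group; compound 1, which also carries trifluoromethyl, gives 61.3% but differs from compound 4 in a second place as well. Compound 4 is therefore expected to show a number 8.5 percentage points higher from compound 3 to compound 4 (within the scatter), a step within the scatter, with an estimate of 53% in a range from 38% to 68%.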

Compound 4, a percentage reported as inhibition, at one concentration (the size of the read-out at that concentration, not a potency): 51%
The estimate for compound 4 lay 2 percentage points above the measured number; the range from low to high includes it.
By their numbers in this assay, from the lowest: compounds 3, 4 and 2 (each within the scatter of the next); then compound 1.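

In this assay this aromatic carbon does not separate the three groups tested there: trifluoromethyl in place of methoxy gives a number 6.5 percentage points higher from compound 3 to compound 4 (within the scatter) and trifluoromethyl in place of ethoxy gives a number 0.2 percentage points lower from compound 2 to compound 4 (within the scatter) on the otherwise shared structure. Carboxy in place of hydroxy gives a number 10.3 percentage points lower from compound 1 to compound 4 (beyond the scatter) and is the only one of these three changes to pass the scatter, and only modestly. Nothing available explains either result. Still open, as far as these compounds go, is whether an amine or a longer chain such as butoxy on this aromatic carbon would stand apart from these groups. Each number also comes from a single concentration, so it speaks only of a stronger or weaker effect at that concentration.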